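The source may hold more compounds than are shown below. What is called first, only, known or untested is meant among the compounds shown, and "the series" means these compounds.

Compound 1 `CNC(=O)CC1CCc2cc(OC)c(OC)cc21` gives 29% in a functional assay on the whole organism (strain Wistar) for inhibition, with Rattus norvegicus as the target, read by paw edema, with stated times of 60 min and 3 h, at a dose of 100 mg/kg by the oral route; a higher number here means more inhibition at the dose given (going by the name of the read-out), a lower number less inhibition.
Compound 2 `COc1cc2c(cc1OC)C(CC(=O)N(C)C)CC2` gives 34.8%.
Compound 3 `CCCCNC(=O)CC1CCc2cc(OC)c(OC)cc21` gives 27.5%.

Compound 3 holds the nominally lowest of the three numbers, yet neither other compound is separated from it: the step of a number 1.5 percentage points lower from compound 1 to compound 3 (within the scatter) and the step of a number 7.3 percentage points lower from compound 2 to compound 3 (within the scatter) both stay within the scatter, so the three compounds are not distinguishable on these figures. Compound 4 `COc1cc2c(cc1OC)C(CC(=O)NC1CCCCC1)CC2` differs from compound 3 by cyclohexyl in place of butyl on an amide-type nitrogen. The measured steps that bear on this are the three that alter what sits on the amide-type nitrogen: a number 5.8 percentage points higher from compound 1 to compound 2 (within the scatter), a number 1.5 percentage points lower from compound 1 to compound 3 (within the scatter) and a number 7.3 percentage points lower from compound 2 to compound 3 (within the scatter). All of them stay within the scatter, and none gives a direction. Among the measured compounds shown here, no measured step places a ring on that nitrogen, so cyclohexyl in place of butyl is judged only by these. Compound 4 is therefore expected to give 28%, with a range from 16% to 40%. The estimated step of a number 0.5 percentage points higher from compound 3 to compound 4 (within the scatter) is not expected to reach beyond the scatter.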

Compound 4, a percentage reported as inhibition, in the whole organism at one dose (the size of the read-out at that dose, not a potency): 49.3%
For compound 4 the middle estimate is 21.3 percentage points below the measured one, outside the stated range (above it).
By their numbers in this assay, from the lowest: compounds 3, 1 and 2 (each within the scatter of the next); then compound 4.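

Among the compounds shown here, on the amide-type nitrogen, cyclohexyl is the first group to carry a compound beyond the scatter in this assay, with a number 21.8 percentage points higher from compound 3 to compound 4 (beyond the scatter) in the change from butyl, and the same holds for a number 20.3 percentage points higher from compound 1 to compound 4 (beyond the scatter) and for a number 14.5 percentage points higher from compound 2 to compound 4 (beyond the scatter) when the group is compared with methyl and with the dimethylamino arrangement. Methyl, dimethylamino and butyl do not separate from one another, so among these compounds only cyclohexyl sets a compound apart. Nothing available accounts for this difference.

The step from butyl to cyclohexyl adds a ring and two carbons at once, so the compounds shown cannot separate the two changes. From the compounds shown here alone, it also remains open whether cyclopentyl, an open branched group such as tert-butyl, or phenyl on that nitrogen would behave like cyclohexyl.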